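Adding a Diethylamino Group to a Thiosemicarbazone

The source may hold more compounds than are shown below. What is called first, only, known or untested is meant among the compounds shown, and "the series" means these compounds.

Of the compounds shown here, two have been measured in a functional assay on SW-620 cells (Homo sapiens) for antiproliferative activity, read by MTT assay, with a stated time of 72 h; a higher number here means a weaker inhibitor, a lower number a stronger inhibitor. Compound 1 `CCN(CC)c1ccc(/C=N/NC(N)=S)c(O)c1` gives 3000 nM. Compound 2 `Oc1ccccc1/C=N/NC(=S)Nc1ccccc1` gives 2000 nM, the lower of the two numbers, although the gap to compound 1 lies within the ordinary scatter of repeated measurements, so the two cannot be ranked against each other. Among the measured compounds shown here, these compounds differ in more than one place, so no single structural step between them can be read off.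

Compound 3 `CCN(CC)c1ccc(/C=N/NC(=S)Nc2ccccc2)c(O)c1` has not yet been measured in this assay. Relative to compound 2, the change is diethylamino in place of hydrogen on an aromatic carbon. The same diethylamino group is present in compound 1, whose number sits close to that of compound 2, so the data give no sign that this group shifts the read-out much in either direction.

On that basis, compound 3 is expected to give about 2000 nM in this assay, with a plausible range from 700 nM to 6000 nM. The step from compound 2 to compound 3 is therefore estimated as no change at the digits printed from compound 2 to compound 3 (within the scatter), which would not exceed the scatter.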

Compound 3, half-maximal inhibitory concentration: 600 nM
The estimate for compound 3 lay 3.3-fold (0.52 log units) above the measured number; the whole stated range lies above it.
By their numbers in this assay, from the lowest: compound 3; then compounds 2 and 1 (each within the scatter of the next).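

In this assay the aromatic carbon meta to the hydroxy group and para to a large group proves responsive: diethylamino in place of hydrogen there gives a 3.3-fold lower number from compound 2 to compound 3 (0.52 log units; beyond the scatter) and this lies beyond the scatter, so with phenyl on the amide-type nitrogen, this change does shift the read-out. The other single change, phenyl in place of hydrogen on the amide-type nitrogen with diethylamino already present, gives a 5.0-fold lower number from compound 1 to compound 3 (0.70 log units; beyond the scatter) and this also lies beyond the scatter, so compound 3, which carries both groups, has the lowest number of the three compounds shown. Nothing measured here says what lies behind either step.

As far as these compounds go, whether a smaller dimethylamino group, a pyrrolidine ring or a carboxylic acid on the same aromatic carbon would lower the number in the same way remains open. Also open is what phenyl on the amide-type nitrogen does when the aromatic carbon carries only hydrogen, so the compounds shown cannot tell whether the two changes simply add up or depend on each other.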